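This account rests on a few compounds, and the source may have more. Where it says the series, first, only, none or still open, it means among the compounds named here.

Measured in a physicochemical assay for lipophilicity; a lower number here means a more polar compound, a higher number a more lipophilic compound:
Compound 1 `CCOc1ccccc1C1=NC(c2ccccc2)CO1`: 4.22
Compound 2 `COc1ccccc1C1=NC(c2ccccc2)CO1`: 3.76
Compound 3 `Fc1ccccc1C1=NC(c2ccccc2)CO1`: 3.51

Compound 3 cannot be told apart from compound 2, with a number 0.25 log units lower from compound 2 to compound 3 (within the scatter), but it stands clear of compound 1, with a number 0.71 log units lower from compound 1 to compound 3 (beyond the scatter). Compound 4 `CCSc1ccccc1C1=NC(c2ccccc2)CO1` carries ethylsulfanyl in place of fluoro on an aromatic carbon, that is, ethylsulfanyl in place of fluoro on an aromatic carbon. The closest guide is the step between compound 1 and compound 3, run in reverse, since ethoxy and ethylsulfanyl have chains of the same name length. The step of a number 0.46 log units lower from compound 1 to compound 2 (beyond the scatter) shows that the chain itself counts. Among the compounds with values here, no measured compound carries sulfur, so the size stays uncertain. A rise somewhat larger than that reversed step is expected, and the estimated change is a number 1.09 log units higher from compound 3 to compound 4 (beyond the scatter). The estimate for compound 4 is 4.6, with an expected range of 4.1 to 5.1.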

Compound 4, partition coefficient: 4.04
Compound 4: middle estimate off by 0.56 log units, on the high side; the measured number lies below the stated range.
By their numbers in this assay, from the lowest: compounds 3, 2, 4 and 1 (each within the scatter of the next, the first and the last beyond it).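

In this assay, ethylsulfanyl on this aromatic carbon stands clear of fluoro (a number 0.53 log units higher from compound 3 to compound 4 (beyond the scatter)). It cannot be told apart from methoxy (a number 0.28 log units higher from compound 2 to compound 4 (within the scatter)) or from ethoxy (a number 0.18 log units lower from compound 1 to compound 4 (within the scatter)), so at this position the sulfur-bearing chain gives a reading indistinguishable from its oxygen counterpart. Nothing available bears on why this is so. Going by these compounds, whether a longer chain on the sulfur, such as propylsulfanyl, would separate from ethylsulfanyl remains open. So does how an amine or a carboxylic acid on this carbon would compare.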